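One Chlorine Fewer on the Benzyl Arm

The compounds below may be only part of what the source reports. "The series", "measured", "known", "first", "only" and "open" are said of these compounds alone.

The three measured compounds share a common core, and compound 1 `Nc1nc(O)c2c(n1)n(C1OC(CO)[C@@H](O)[C@H]1O)c(=O)n2Cc1ccc(Cl)c(Cl)c1` carries a 3,4-dichlorobenzyl group on it. In a functional assay on YAC-1 cells (Mus musculus) (a lower number here means a smaller maximal response, a higher number a larger maximal response), compound 1 gives 15%. Compound 2 `CCCn1c(=O)n(C2OC(COP(=O)(O)O)[C@@H](O)[C@H]2O)c2nc(N)nc(O)c21` gives 15% in this assay, and compound 3 `C=CCn1c(=O)n([C@H]2CO[C@@H](CO)C2)c2nc(N)nc(O)c21` gives 0%. Compound 1 therefore stands level with compound 2 at the digits shown, the two together being the highest of the three numbers, while compound 3 lies below both by a gap beyond the usual scatter.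

Compound 4 `Nc1nc(O)c2c(n1)n(C1OC(CO)[C@@H](O)[C@H]1O)c(=O)n2Cc1ccc(Cl)cc1` has not yet been measured in this assay. It differs from compound 1 in one place: hydrogen in place of chloro on an aromatic carbon. Within the data shown here, no pair of measured compounds isolates this change, so its effect is not known from the numbers so far. Because compound 1 gives only 15% and the change removes a single chloro group from the benzyl arm, the step is expected to be small, most likely a slight decrease or none beyond the scatter. The step of a number 3 percentage points lower from compound 1 to compound 4 (within the scatter) is expected to stay within the scatter. Compound 4 is estimated to give 12% in this assay, with a range from 0% to 25%.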

Compound 4, largest response reached (reported as maximal response), in percent of the reference or control that the assay uses: 27%
Compound 4: middle estimate off by 15 percentage points, on the low side; measured number above the stated range.
By their numbers in this assay, from the lowest: compound 3; then compounds 1 and 2 (each within the scatter of the next); then compound 4.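

Among these compounds, the pair gives the first reading of this position on the benzyl arm, since no earlier pair of compounds isolated it. In this assay, going from 3,4-dichlorobenzyl to 4-chlorobenzyl gives a number 12 percentage points higher from compound 1 to compound 4 (beyond the scatter), so the chloro group ortho to the remaining chloro group is not required for the maximal response seen with compound 1, and hydrogen on this aromatic carbon gives the larger number of the two. With the rest of the structure unchanged, the loss of this one chlorine atom accounts for the whole step, though nothing measured here explains how it raises the response.

The compounds shown leave open whether hydrogen is special at this aromatic carbon, or whether a fluoro, methyl or methoxy group there would read like hydrogen or like chloro. They also leave open what the remaining chloro group contributes, as a plain unsubstituted benzyl group would test that directly, and whether the same step would hold on a shared core carrying a phosphate in place of the free hydroxymethyl group.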